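A few compounds are considered here, and "the series" means these few. Any claim that something is new, unique, unknown or untested is made for them only; others in the source may bear on it.

Measured in a functional assay on the whole organism (strain Kunming) with Mus musculus as the target, with a stated time of 0.5 h; on this read-out higher numbers stand for an effect only at larger amounts of compound and lower numbers for an effect already at smaller amounts:
Compound 1 `COc1cc(OC)c(OC)cc1/C=C/COC(=O)/C=C/c1ccc(OC)c(OC)c1`: > 723 umol/kg, a limit of the assay and not a number
Compound 2 `COc1cc(OC)c(OC)cc1/C=C/COC(=O)/C=C/c1ccccc1Cl`: 639 umol/kg
Compound 3 `COc1cccc(/C=C/C(=O)OC/C=C/c2cc(OC)c(OC)cc2OC)c1`: 647 umol/kg

Compound 3, at 647 umol/kg, cannot be told apart from its nearest measured neighbour, with a 1.0-fold higher number from compound 2 to compound 3 (0.01 log units; within the scatter). The unmeasured compound 4 `COc1ccc(/C=C/C(=O)OC/C=C/c2cc(OC)c(OC)cc2OC)cc1` carries 4-methoxyphenyl in place of 3-methoxyphenyl on a double-bonded chain carbon bound to a double-bonded chain carbon. Going by the values given here, three measured steps bear on this place. Hydrogen in place of methoxy gave an at least 1.1-fold lower number from compound 1 to compound 3 (0.04 log units; that floor lies within the scatter), and 2-chlorophenyl in place of 3,4-dimethoxyphenyl gave an at least 1.1-fold lower number from compound 1 to compound 2 (0.05 log units; that floor lies within the scatter). Both of these start from compound 1, whose reading is the limit of > 723 umol/kg in this assay, at which 1 of the 3 values shown sits. The third exchange, 3-methoxyphenyl in place of 2-chlorophenyl, gave a 1.0-fold higher number from compound 2 to compound 3 (0.01 log units; within the scatter). None of these steps leaves the scatter, so no step beyond the scatter is expected here. In this assay the expected change is a 1.0-fold lower number from compound 3 to compound 4 (0.02 log units; within the scatter). Compound 4 is estimated at 620 umol/kg, with an expected range of 350 umol/kg to 1000 umol/kg.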

Compound 4, dose for half-maximal effect: > 780 umol/kg
Compound 4 was reported as a limit; the forecaster's own chance of this, stated with the estimate: 30%; at least 1.2-fold (0.09 log units) between middle value and limit.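

In this assay, 4-methoxyphenyl in place of 3-methoxyphenyl gave an at least 1.2-fold higher number from compound 3 to compound 4 (0.08 log units; that floor lies within the scatter), so this exchange at the same place turned a measured number into a limit of the assay, though that floor does not show a real difference. Against the 2-chlorophenyl group, 4-methoxyphenyl gave an at least 1.2-fold higher number from compound 2 to compound 4 (0.08 log units; that floor lies within the scatter), which again shows only a floor inside the scatter. The step between compound 1 and compound 4 cannot be read, as compound 4 too reads only as a limit: the limit of > 780 umol/kg in this assay, at which 1 of the 4 values shown sits.

On these data alone, how far compound 4 truly lies from compound 3 stays open, as does whether any exchange at this place leaves the scatter at all. Also open, as far as these compounds go, is what an amine or a carboxylic acid on this phenyl group would do in this assay.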